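The compounds below may be only part of what the source reports. "The series", "measured", "known", "first", "only" and "open" are said of these compounds alone.

Compound 3 `C=C(Br)C(=O)Nc1cccc(-c2cn3nc(Cc4cccc(OC)c4)sc3n2)c1` gives 3100 nM in a functional assay on CCRF-CEM cells (Homo sapiens) for inhibition, read by cell counting, with a stated time of 3 days (on this read-out higher numbers stand for weaker inhibition and lower numbers for stronger inhibition), the highest of the three numbers: compound 1 `C=C(Br)C(=O)Nc1cccc(-c2cn3nc(-c4ccc(OC)c(OC)c4)sc3n2)c1` gives 380 nM and compound 2 `C=C(Br)C(=O)Nc1cccc(-c2cn3nc(-c4ccc(OCC)cc4)sc3n2)c1` gives 1400 nM, both lower. Compound 4 `C=C(Br)C(=O)Nc1cccc(-c2cn3nc(CCc4ccccc4)sc3n2)c1` differs from compound 3 by benzyl in place of 3-methoxyphenyl on a saturated chain carbon bound to an aromatic carbon. Going by the values given here, no measured step strips the methoxy group away or lengthens the chain; the nearest steps, a 2.2-fold higher number from compound 2 to compound 3 (0.35 log units; beyond the scatter) and an 8.2-fold higher number from compound 1 to compound 3 (0.91 log units; beyond the scatter), each swap the whole aryl piece, so they only hint that this part of the molecule moves the number. Compound 4 is therefore expected to shift by a 1.5-fold higher number from compound 3 to compound 4 (0.16 log units; within the scatter) in this assay, a change not clearly beyond the scatter. Compound 4 is estimated at 4500 nM, within 1500 nM to 13000 nM.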

Compound 4, half-maximal inhibitory concentration: 4200 nM
Compound 4: middle estimate off by 1.1-fold (0.03 log units), on the high side; measured number inside the range.
By their numbers in this assay, from the lowest: compound 1; then compound 2; then compounds 3 and 4 (each within the scatter of the next).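

In this assay the change from 3-methoxybenzyl to phenethyl gives a 1.4-fold higher number from compound 3 to compound 4 (0.13 log units; within the scatter) and so does not separate these two side chains. Phenethyl still stands apart from the two aryl groups, with a 3.0-fold higher number from compound 2 to compound 4 (0.48 log units; beyond the scatter) for 4-ethoxyphenyl and an 11-fold higher number from compound 1 to compound 4 (1.04 log units; beyond the scatter) for 3,4-dimethoxyphenyl, the only large step among the compounds shown. No evidence at hand accounts for these steps. As far as these compounds go, the loss of the methoxy group and the change in the chain fall in one step, so their separate shares remain open. From the compounds shown here alone, how an amine or a carboxylic acid in place of that methoxy group, or a chain longer than phenethyl, would read also remains open.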